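The source may report more compounds than this note shows. Statements on the series, on what has been measured and on what is new or still open speak of the compounds shown alone.

Working notes on the series. Compound 1 `COc1cc(-c2nn(-c3cccc(NC(=O)c4ccc(Cl)c(C(F)(F)F)c4)c3)cc2-c2ccncc2)ccc1Cl` carries an amide on the shared core and in a functional assay on HCT-15 cells (Homo sapiens) for inhibition, read by sulforhodamine B assay, with a stated time of 48 h (on this read-out lower numbers stand for stronger inhibition of growth and higher numbers for weaker inhibition of growth), compound 1 gives 3250 nM. Going by the values given here, compound 3 `COc1cc(-c2nn(-c3cccc(NC(=O)Nc4cccc(C(F)(F)F)c4)c3)cc2-c2ccncc2)ccc1Cl` replaces the amide by a urea; in this assay compound 3 gives 870 nM, and the step of a 3.7-fold lower number from compound 1 to compound 3 (0.57 log units; beyond the scatter) is the only single-point change measured so far. Compound 2 `O=C(Nc1cccc(-n2cc(-c3ccncc3)c(-c3ccc(Cl)c(O)c3)n2)c1)Nc1cc(C(F)(F)F)cc(C(F)(F)F)c1` differs from compound 3 in two places at once and in this assay compound 2 gives 474 nM; the two values lie within the scatter of each other, so nothing beyond a shared level can be read from them. Compound 3 thus stands with the second highest number of the three, close to compound 2 and well apart from compound 1.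

Compound 4 `COc1cc(-c2nn(-c3cccc(NC(=O)Nc4cc(C(F)(F)F)cc(C(F)(F)F)c4)c3)cc2-c2ccncc2)ccc1Cl` is the next single-point change from compound 3: trifluoromethyl in place of hydrogen on an aromatic carbon. Among the compounds with values here, no measured step covers this exact change; the comparison of compound 2 with compound 3, with its second difference, is the nearest guide and suggests little movement. Compound 4 is expected near compound 3, with a step of a 1.5-fold lower number from compound 3 to compound 4 (0.16 log units; within the scatter) at most modest, and an estimated value of 600 nM with a range from 250 nM to 1500 nM.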

Compound 4, concentration for 50% growth inhibition: 617 nM
For compound 4 the middle estimate is 1.0-fold (0.01 log units) below the measured one; measured number inside the range.
By their numbers in this assay, from the lowest: compounds 2, 4 and 3 (each within the scatter of the next); then compound 1.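

In this assay, going by these compounds alone, the step of a 1.4-fold lower number from compound 3 to compound 4 (0.15 log units; within the scatter) gives the first direct reading of trifluoromethyl in place of hydrogen at this place on the six-membered aromatic ring of carbon only, and the change stays within the scatter. The step of a 1.3-fold higher number from compound 2 to compound 4 (0.11 log units; within the scatter) separates methyl in place of hydrogen on an oxygen on an aromatic ring from the second difference that blurred the comparison of compound 2 with compound 3, and this change also stays within the scatter. No information on why either change leaves the number within the scatter is available.

Open, from the compounds shown here alone, is whether an amine or a carboxylic acid in place of this trifluoromethyl group would also stay within the scatter. Also open, going by these compounds, is whether a longer chain in place of the methyl on the oxygen would do so.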